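Cytotoxicity notes: aryl-to-arylsulfanyl swap on the shared core

The source may report more compounds than this note shows. Statements on the series, on what has been measured and on what is new or still open speak of the compounds shown alone.

Measured compounds so far:
- compound 1, `Cc1cc(-c2ccc3[nH]ccc3c2)cn2c(CSCCc3ccccc3)cnc12`: 26 ug/mL
- compound 2, `Cc1cc(C#N)cn2c(CSCCc3ccccc3)cnc12`: 14 ug/mL
- compound 3, `Cc1cc(-c2ccco2)c2ncc(CSCCc3ccccc3)n2c1`: 41 ug/mL

All three numbers come from an ADME assay on HEL cells (Homo sapiens) for cytotoxicity, with a stated time of 3 days; on this read-out higher numbers stand for lower toxicity in this test and lower numbers for higher toxicity in this test. Compound 3 stands highest of the three; compound 1 sits nearest, and the gap between compound 3 and compound 1 is within the scatter, while compound 2 lies furthest, beyond the scatter from compound 3.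

Within the data shown here, the only measured step within the set is the one from compound 1 to compound 2, a 1.9-fold lower number from compound 1 to compound 2 (0.27 log units; within the scatter), a replacement of one aromatic substituent by a much smaller one that left the number where it was.

Compound 4, `Cc1cc(Sc2ccc(Cl)cc2)c2ncc(CSCCc3ccccc3)n2c1`, has not yet been measured. It differs from compound 3 by (4-chlorophenyl)sulfanyl in place of furan-2-yl on an aromatic carbon. Among the measured compounds shown here, no measured pair exchanges a furan-2-yl for a (4-chlorophenyl)sulfanyl, so the step from compound 1 to compound 2 is the closest analogy: a change of the substituent at a comparable site that stayed within the scatter. On that basis the expected step from compound 3 to compound 4 is a 1.3-fold lower number from compound 3 to compound 4 (0.11 log units; within the scatter), which is taken to be no change beyond the scatter, with a wide allowance for the different group entering.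

Compound 4 is therefore expected to give about 32 ug/mL in this assay, with a range from 12 ug/mL to 85 ug/mL.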

Compound 4, half-maximal cytotoxic concentration: 100 ug/mL
Beside the measured number, compound 4's estimate is 3.1-fold (0.49 log units) below it, outside the stated range (above it).
By their numbers in this assay, from the lowest: compounds 2, 1 and 3 (each within the scatter of the next, the first and the last beyond it); then compound 4.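

In this assay, among these compounds, (4-chlorophenyl)sulfanyl in place of furan-2-yl, on the aromatic carbon ortho to a fused ring and meta to a methyl group, gives a 2.4-fold higher number from compound 3 to compound 4 (0.39 log units; beyond the scatter) and so clears the scatter, whereas the only earlier step, a 1.9-fold lower number from compound 1 to compound 2 (0.27 log units; within the scatter) at another aromatic carbon, stayed within it. At this position, a five-membered aromatic ring with 1 hetero atom gives way to a six-membered aromatic ring of carbon only, and the count rises from 5 to 8 heavy atoms, yet the number moves up rather than down, so this larger group brings no sign of higher toxicity in this test. Nothing available explains the rise.

The compounds shown do not separate the contributions of the sulfur link, the chlorine and the loss of the furan-2-yl ring, so a plain phenylsulfanyl group or a 4-chlorophenyl group joined directly to the aromatic carbon would be the informative comparisons. On these data alone, whether an amine or a carboxylic acid at this position would keep the number up also remains open.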